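Swapping Sulfamoyl for Methylsulfanyl on a Phosphodiesterase Inhibitor

The compounds below may be only part of what the source reports. "The series", "measured", "known", "first", "only" and "open" are said of these compounds alone.

Three compounds share one core and differ only in the group on the outer phenyl ring. In an in vitro assay on Sf21 cells for inhibition of high affinity 3',5'-cyclic-AMP phosphodiesterase 7A (Homo sapiens), read by scintillation proximity assay, with a stated time of 30 min (on this read-out lower numbers stand for stronger inhibition and higher numbers for weaker inhibition), compound 1 `Nc1ccc(NC(=O)c2cn(Cc3c(F)cccc3F)c3ccc(=O)[nH]c3c2=O)cc1` gives 104 nM, compound 2 `O=C(NCc1ccncc1)c1ccc(NC(=O)c2cn(Cc3c(F)cccc3F)c3ccc(=O)[nH]c3c2=O)cc1` gives 20 nM, and compound 3 `NS(=O)(=O)c1ccc(NC(=O)c2cn(Cc3c(F)cccc3F)c3ccc(=O)[nH]c3c2=O)cc1` gives 34 nM. The number for compound 3 is the middle one of the three, with a 1.7-fold higher number from compound 2 to compound 3 (0.23 log units; within the scatter) and a 3.1-fold lower number from compound 1 to compound 3 (0.49 log units; beyond the scatter). As far as these compounds go, compound 4 `CSc1ccc(NC(=O)c2cn(Cc3c(F)cccc3F)c3ccc(=O)[nH]c3c2=O)cc1` is untested; the change is methylsulfanyl in place of sulfamoyl on an aromatic carbon. Among the compounds with values here, no measured step covers this swap; the closest evidence is a 3.1-fold lower number from compound 1 to compound 3 (0.49 log units; beyond the scatter) and a 5.2-fold lower number from compound 1 to compound 2 (0.72 log units; beyond the scatter), showing that the group at this position can move the number beyond the scatter. Compound 4 is therefore expected to give 80 nM, within 25 nM to 250 nM. The estimated step is a 2.4-fold higher number from compound 3 to compound 4 (0.37 log units; beyond the scatter), toward a weaker result, held with wide uncertainty.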

Compound 4, half-maximal inhibitory concentration: 86 nM
For compound 4 the middle estimate is 1.1-fold (0.03 log units) below the measured one; the range from low to high includes it.
By their numbers in this assay, from the lowest: compounds 2 and 3 (each within the scatter of the next); then compounds 4 and 1 (each within the scatter of the next).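

At this position, para to a large group, methylsulfanyl falls behind sulfamoyl, with a 2.5-fold higher number from compound 3 to compound 4 (0.40 log units; beyond the scatter), and also behind ((pyridin-4-yl)methyl)carbamoyl, with a 4.3-fold higher number from compound 2 to compound 4 (0.63 log units; beyond the scatter). Against amino it brings no real change, with a 1.2-fold lower number from compound 1 to compound 4 (0.08 log units; within the scatter), so the two lower numbers so far belong to compound 2 and compound 3, not to every replacement of amino. Nothing measured here explains this difference. As far as these compounds go, it remains open whether the sulfamoyl result depends on its oxygens or its nitrogen, and a methylsulfonyl group at the same place would help separate the two.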